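Replacing the ring-nitrogen cap in compound 2

The source may hold more compounds than are shown below. What is called first, only, known or untested is meant among the compounds shown, and "the series" means these compounds.

Measured compounds:
compound 1, `CCCCOC(=O)N1CCC(Oc2ncnc3c2CCN3c2ccc(S(C)(=O)=O)cc2F)CC1`, 50.1 nM
compound 2, `CC(C)c1noc(N2CCC(Oc3ncnc4c3CCN4c3ccc(S(C)(=O)=O)cc3F)CC2)n1`, 79.4 nM

Both were tested in a functional assay on CHO-K1 cells for agonist activity at Glucose-dependent insulinotropic receptor (Homo sapiens), read by a luciferase reporter, with a stated time of 5 h; a lower number here means that less compound is needed, a higher number that more compound is needed for the effect. Among the two numbers compound 2 gives the higher one, but its only neighbour, compound 1, lies within the scatter: a 1.6-fold higher number from compound 1 to compound 2 (0.20 log units; within the scatter). So the swap of a butoxycarbonyl for a 3-isopropyl-1,2,4-oxadiazol-5-yl on the ring amine nitrogen leaves the read-out essentially unchanged.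

Compound 3, `CS(=O)(=O)c1ccc(N2CCc3c(OC4CCN(C5=NCCCN5)CC4)ncnc32)c(F)c1`, has not been measured. It differs from compound 2 in one place: a group of 6 heavy atoms (4 carbon, 2 nitrogen; one six-membered non-aromatic ring with 2 hetero atoms) in place of a group of 8 heavy atoms (5 carbon, 2 nitrogen, 1 oxygen; one five-membered aromatic ring with 3 hetero atoms), on an amine nitrogen in a ring. Within the data shown here, the single measured step bears on this position only loosely; it tells that one exchange of a neutral cap for another costs little, but the group that enters here carries a hydrogen-bond donor and no aromatic ring, which neither measured compound covers. Among the measured compounds shown here, with no measured step of that kind to lean on, a moderately larger half-maximal effective concentration is expected for compound 3, with wide uncertainty; the estimated step is a 3.1-fold higher number from compound 2 to compound 3 (0.50 log units; beyond the scatter). Compound 3 is thus estimated at 250 nM, within a range of 50 nM to 1200 nM.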

Compound 3, half-maximal effective concentration: 2000 nM
Beside the measured number, compound 3's estimate is 8.0-fold (0.90 log units) below it; the measured number lies above the stated range.
By their numbers in this assay, from the lowest: compounds 1 and 2 (each within the scatter of the next); then compound 3.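

In this assay the amine nitrogen in the ring does not take every cap alike: the six-membered non-aromatic ring with 2 hetero atoms gives a 25-fold higher number from compound 2 to compound 3 (1.40 log units; beyond the scatter) when it replaces the 3-isopropyl-1,2,4-oxadiazol-5-yl, and a 40-fold higher number from compound 1 to compound 3 (1.60 log units; beyond the scatter) when it replaces the butoxycarbonyl. The earlier pair offered only two caps that this read-out could not tell apart, whereas compound 3 shows that the read-out responds strongly to what sits on this nitrogen. Nothing available explains the size of these steps, and the hydrogen-bond donor, the missing aromatic ring and the double bond of the entering group remain undivided as candidates.

The compounds shown leave open which of these features matters: a pyrimidin-2-yl group or a cyclic urea on the same nitrogen would keep part of the entering group and change the rest. They also leave open how widely the neutral caps hold up, for instance an ethoxycarbonyl or a 3-methyl-1,2,4-oxadiazol-5-yl in place of the two groups in compound 1 and compound 2.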